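Moving and swapping a phenyl substituent on the triazole nitrogen

The source may hold more compounds than are shown below. What is called first, only, known or untested is meant among the compounds shown, and "the series" means these compounds.

Measured compounds:
- Compound 1 `Cc1ccccc1-n1cc(-c2ccccc2NS(=O)(=O)c2c[nH]c(=O)[nH]c2=O)nn1`: 9570 nM
- Compound 2 `Cc1cccc(-n2cc(-c3ccccc3NS(=O)(=O)c3c[nH]c(=O)[nH]c3=O)nn2)c1`: 3510 nM
- Compound 3 `Cc1ccc(-n2cc(-c3ccccc3NS(=O)(=O)c3c[nH]c(=O)[nH]c3=O)nn2)cc1`: 6390 nM

All three compounds share a common core and differ only in the methylphenyl group attached to an aromatic nitrogen. In a functional assay on SGC-7901 cells (Homo sapiens) for antiproliferative activity, read by MTT assay, with a stated time of 24 h (on this read-out lower numbers stand for stronger inhibition and higher numbers for weaker inhibition), compound 1 gives 9570 nM, the highest number of the three. The step of a 2.7-fold lower number from compound 1 to compound 2 (0.44 log units; beyond the scatter) is the only one that goes beyond the scatter; the step of a 1.5-fold lower number from compound 1 to compound 3 (0.18 log units; within the scatter) and the step of a 1.8-fold higher number from compound 2 to compound 3 (0.26 log units; within the scatter) stay within it.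

Compound 4 `O=c1[nH]cc(S(=O)(=O)Nc2ccccc2-c2cn(-c3cccc(Cl)c3)nn2)c(=O)[nH]1` has not yet been measured. Its change from compound 1 is 3-chlorophenyl in place of 2-methylphenyl on an aromatic nitrogen. Two things happen at once here: the substituent moves from the 2-methylphenyl arrangement to a 3-substituted one, and methyl is replaced by chlorine. Only the first part has a measured counterpart, the step of a 2.7-fold lower number from compound 1 to compound 2 (0.44 log units; beyond the scatter), which was modest but real. Nothing measured here tells how chlorine compares with methyl, so that part adds uncertainty rather than direction.

The expectation for compound 4 is therefore a modest step in this assay, with a lower number than compound 1, roughly a 2.4-fold lower number from compound 1 to compound 4 (0.38 log units; beyond the scatter). Compound 4 is estimated at 4000 nM, within a range from 1500 nM to 11000 nM.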

Compound 4, half-maximal inhibitory concentration: 2270 nM
Compound 4: middle estimate off by 1.8-fold (0.25 log units), on the high side; measured number inside the range.
By their numbers in this assay, from the lowest: compounds 4, 2, 3 and 1 (each within the scatter of the next, the first and the last beyond it).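

In this assay, going by these compounds alone, the only direct comparison of chloro with methyl on this phenyl group (a 1.5-fold lower number from compound 2 to compound 4 (0.19 log units; within the scatter)) stays within the scatter, so swapping one for the other in the 3-substituted arrangement shows no real difference. Compound 4 does give a clearly lower number than the other two compounds (a 4.2-fold lower number from compound 1 to compound 4 (0.62 log units; beyond the scatter); a 2.8-fold lower number from compound 3 to compound 4 (0.45 log units; beyond the scatter)), although each of these steps changes both the substituent and where it sits. Nothing available here explains why the numbers fall this way.

The compounds shown leave open how 2-chlorophenyl and 4-chlorophenyl would compare with compound 1 and compound 3, which would separate the effect of the atom from that of its place. They also leave open what a methoxy group, an amine or a carboxylic acid on this phenyl ring would do to the number.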